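Dimethylamino for benzylsulfanyl on a nucleoside core

The source may report more compounds than this note shows. Statements on the series, on what has been measured and on what is new or still open speak of the compounds shown alone.

Compound 1 `OC[C@H]1OC(n2cnc3c(SCc4ccccc4)nccc32)[C@H](O)[C@@H]1O` has the higher of the two numbers measured in a functional assay (Homo sapiens) for inhibition of Nucleic Acid, tested at 100 uM; on this read-out higher numbers stand for more inhibition at the one concentration tested (going by the name of the read-out) and lower numbers for less inhibition: compound 1 gives 30%, while compound 2 `CN(C)c1nccc2c1ncn2[C@H]1C[C@H](O)[C@@H](CO)O1` gives 0%, a gap beyond the usual scatter. Compound 3 `CN(C)c1nccc2c1ncn2C1O[C@H](CO)[C@@H](O)[C@H]1O` has not yet been tested. It differs from compound 1 by dimethylamino in place of benzylsulfanyl on an aromatic carbon. Because compound 2, which also carries a dimethylamino group, gives 0%, a step downward is expected from compound 1 to compound 3, and that expected step is a number 25 percentage points lower from compound 1 to compound 3 (beyond the scatter). For compound 3 the estimate in this assay is 5%, within a range from -10% to 25%.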

Compound 3, a percentage reported as inhibition, at one concentration (the size of the read-out at that concentration, not a potency): 0%
Estimate against measurement, compound 3: 5 percentage points above; measured number inside the range.
By their numbers in this assay, from the lowest: compounds 2 and 3 (each within the scatter of the next); then compound 1.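

In this assay, replacing benzylsulfanyl with dimethylamino on this aromatic carbon, with the rest of compound 1 unchanged, gives a number 30 percentage points lower from compound 1 to compound 3 (beyond the scatter). Going by these compounds alone, the earlier pair differed in more than one place, so this is the first reading of this position alone, and it shows that the inhibition depends on the group held here. Nothing given here accounts for the step. From the compounds shown here alone, whether it follows the sulfur or the benzyl part remains open; methylsulfanyl or benzylamino on this carbon would separate the two.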